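Replacing the Phenyl Group of Compound 2

The source may report more compounds than this note shows. Statements on the series, on what has been measured and on what is new or still open speak of the compounds shown alone.

In a functional assay on DU-145 cells (Homo sapiens) for cytotoxicity, read by MTT assay, with a stated time of 48 h (a lower number here means a stronger inhibitor, a higher number a weaker inhibitor), two compounds on a shared core have been measured so far. Compound 1 `COc1ccc(/C=C/c2cc(OC)c(OC)c(OC)c2-c2ccc(F)c(F)c2)cc1` stands at 7500 nM and compound 2 `COc1ccc(/C=C/c2cc(OC)c(OC)c(OC)c2-c2ccccc2)cc1` at 51000 nM as the higher of the two numbers, which makes it the weaker inhibitor of the pair. For the measured compounds named here, the only measured step is phenyl in place of 3,4-difluorophenyl on an aromatic carbon, which gives a 6.8-fold higher number from compound 1 to compound 2 (0.83 log units; beyond the scatter) and is the sole guide here.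

Compound 3 `COc1ccc(/C=C/c2cc(OC)c(OC)c(OC)c2-c2ccc3ccccc3c2)cc1` differs from compound 2 at that same place, with naphthalen-2-yl in place of phenyl on an aromatic carbon, counted as naphthalen-2-yl in place of phenyl on an aromatic carbon in the two structures. Going by the values given here, no compound with naphthalen-2-yl has been measured, so the guide is indirect. Going by compound 2 with 51000 nM at the high end and by the modest size of a 6.8-fold higher number from compound 1 to compound 2 (0.83 log units; beyond the scatter) in the one known change at this place, a modest step to a lower number is expected in this assay although no step beyond the scatter remains possible. An estimated 3.2-fold lower number from compound 2 to compound 3 (0.50 log units; beyond the scatter) is what this expectation means. For compound 3 the estimated value is 16000 nM with 4000 nM to 60000 nM as the expected range.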

Compound 3, half-maximal inhibitory concentration: 32000 nM
Compound 3: the middle estimate sits 2.0-fold (0.30 log units) below what was measured, within the range that was stated.
By their numbers in this assay, from the lowest: compound 1; then compounds 3 and 2 (each within the scatter of the next).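

At the aromatic carbon ortho to a large group, the phenyl of compound 2 can give way to naphthalen-2-yl, with its two six-membered aromatic rings of carbon only, without a step beyond the scatter in this assay (a 1.6-fold lower number from compound 2 to compound 3 (0.20 log units; within the scatter)). The same place still separates 3,4-difluorophenyl from naphthalen-2-yl (a 4.3-fold higher number from compound 1 to compound 3 (0.63 log units; beyond the scatter)), so compound 1 now stands apart from both of the other compounds, whose fluorine-free groups are not told apart by this read-out. Nothing at hand explains why compound 1 stands apart or why the added ring leaves the number within the scatter.

The compounds shown leave open whether both fluorines of compound 1 are needed, a question that 4-fluorophenyl or 3-fluorophenyl at this place would address. They also leave open how the place would respond to a ring carrying an amine or a carboxylic acid, or to a saturated group such as cyclohexyl in place of the aromatic ring.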